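Moving the amine on the oxygen core: compound 3 to compound 4

The source may report more compounds than this note shows. Statements on the series, on what has been measured and on what is new or still open speak of the compounds shown alone.

Of the compounds shown here, three have been measured in an assay on isolated protein for inhibition of RAC-alpha serine/threonine-protein kinase (Homo sapiens); a lower number here means a stronger inhibitor, a higher number a weaker inhibitor. Compound 1 `CC(C)NCC(Cc1ccc(Cl)c(F)c1)C(=O)N1CCN(c2ncnc3c2[C@H](C)SC3)CC1` gives 2 nM in this assay. Compound 2 `C[C@@H]1SCc2ncnc(N3CCN(C(=O)C(Cc4ccc(Cl)c(F)c4)CC(C)(C)N)CC3)c21` gives 7 nM. Compound 3 `CC(C)NCC(Cc1ccc(Cl)c(F)c1)C(=O)N1CCN(c2ncnc3c2[C@H](C)OC3)CC1` gives 6 nM, which places it second highest of the three numbers; its nearest neighbour is compound 2, within the scatter, while compound 1 lies furthest from it, beyond the scatter. Compound 3 itself arises from compound 1 through a 3.0-fold higher number from compound 1 to compound 3 (0.48 log units; beyond the scatter), a modest loss.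

The unmeasured compound 4 `C[C@@H]1OCc2ncnc(N3CCN(C(=O)C(Cc4ccc(Cl)c(F)c4)CC(C)(C)N)CC3)c21` differs from compound 3 in one place: 1-amino-1-methylethyl in place of isopropylamino on a saturated chain carbon, two bonds along the chain from a carbonyl carbon. The same rearrangement has already been made once, on the sulfur-containing core, and there it read a 3.5-fold higher number from compound 1 to compound 2 (0.54 log units; beyond the scatter), a modest weakening. Within the data shown here, that single step is the only direct precedent, and it bears squarely on the present one, since compound 3 and compound 4 stand to each other exactly as compound 1 and compound 2 do.

Compound 4 is therefore expected to show a weakening of similar size, a 3.5-fold higher number from compound 3 to compound 4 (0.54 log units; beyond the scatter). The estimate for compound 4 in this assay is 21 nM, with a range from 8 nM to 55 nM.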

Compound 4, half-maximal inhibitory concentration: 18 nM
For compound 4 the middle estimate is 1.2-fold (0.07 log units) above the measured one; measured number inside the range.
By their numbers in this assay, from the lowest: compound 1; then compounds 3 and 2 (each within the scatter of the next); then compound 4.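

Replacing isopropylamino with 1-amino-1-methylethyl on the saturated chain carbon gives a 3.0-fold higher number from compound 3 to compound 4 (0.48 log units; beyond the scatter), so a change previously read only on the core of compound 1 now has a second reading on the core of compound 3, and the two agree in size: the same change on two cores in this assay, a 3.5-fold higher number (0.54 log units; beyond the scatter) from compound 1 to compound 2 and a 3.0-fold higher number (0.48 log units; beyond the scatter) from compound 3 to compound 4, 1.2-fold (0.07 log units) apart, within the scatter of two such steps. The exchange of cores also gains a second reading, now with 1-amino-1-methylethyl in place, where it gives a 2.6-fold higher number from compound 2 to compound 4 (0.41 log units; beyond the scatter), and this agrees in size with the step read with isopropylamino: the same change on two cores in this assay, a 3.0-fold higher number (0.48 log units; beyond the scatter) from compound 1 to compound 3 and a 2.6-fold higher number (0.41 log units; beyond the scatter) from compound 2 to compound 4, 1.2-fold (0.07 log units) apart, within the scatter of two such steps. Across these four compounds in this assay, each change therefore reads about the same whichever form of the other is present, and compound 4, which carries both, has the highest number of the four.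

The compounds shown leave open whether the two steps would stay this close with a pyrrolidine or a longer amine chain in place of these two groups, or with a methylene group in place of the ring sulfur or oxygen. As far as these compounds go, all four also share the same chlorofluorophenyl group, so the behaviour of these steps with an unsubstituted phenyl group remains open too.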